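Isopropyl on the amidine: cytotoxicity of a benzofuran pair

The source may report more compounds than this note shows. Statements on the series, on what has been measured and on what is new or still open speak of the compounds shown alone.

Measured so far:
compound 1 `CC(C)NC(=N)c1ccc2oc(-c3cccc(OCCCCOc4ccccc4)c3)cc2c1` with 36500 nM
compound 2 `N=C(N)c1ccc2cc(-c3cccc(OCCCOc4ccccc4)c3)oc2c1` with 19800 nM

Of the compounds shown here, two have been measured in an ADME assay on L6 cells (Rattus norvegicus) for cytotoxicity, read by resazurin assay, with a stated time of 70 h; a lower number here means a stronger inhibitor, a higher number a weaker inhibitor. Compound 1 `CC(C)NC(=N)c1ccc2oc(-c3cccc(OCCCCOc4ccccc4)c3)cc2c1` gives 36500 nM in this assay. Compound 2 `N=C(N)c1ccc2cc(-c3cccc(OCCCOc4ccccc4)c3)oc2c1` gives 19800 nM in this assay. The two numbers lie within the scatter of each other, so nothing separates them with confidence; compound 2 simply stands beside compound 1, and since the two structures differ in more than one place, their pair shows only that both fall in the same region.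

Compound 3 `CC(C)NC(=N)c1ccc2cc(-c3cccc(OCCCOc4ccccc4)c3)oc2c1` is the next compound, and it has not yet been measured in this assay. Against compound 2, the change is isopropyl in place of hydrogen on an amine nitrogen. Among the measured compounds shown here, no measured pair shows this single change on its own, so the size of the step rests on the two numbers already seen. Because compound 1, which carries this same isopropyl group, gives 36500 nM, no step beyond the scatter is expected in either direction. Compound 3 is therefore estimated at 28000 nM in this assay, with a likely range from 10000 nM to 80000 nM. The expected step is a 1.4-fold higher number from compound 2 to compound 3 (0.15 log units; within the scatter), within the scatter.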

Compound 3, half-maximal inhibitory concentration: 82300 nM
Compound 3: middle estimate off by 2.9-fold (0.47 log units), on the low side, and the stated range ends below it.
By their numbers in this assay, from the lowest: compounds 2 and 1 (each within the scatter of the next); then compound 3.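

With isopropyl in place of hydrogen on an amine nitrogen, the change now has a reading of its own in this assay: it gives a 4.2-fold higher number from compound 2 to compound 3 (0.62 log units; beyond the scatter), a modest but clear step. The first two compounds differ in more than one place and could not isolate any single change, whereas here everything outside this amine nitrogen stays the same, so the step belongs to this one replacement on this core. Nothing among the data at hand accounts for the step, and no measurement explains why this replacement moves the number in this direction.

On these data alone, it remains open how a smaller or a ring-bearing group on the same amine nitrogen, such as an ethyl or a cyclopentyl, would read in this assay, and so whether the number follows the group placed there or whether isopropyl stands apart. Among the compounds shown here, with only this one pair in hand, it also remains open whether the same replacement would give a step of similar size on the core of compound 1 , with its longer chain.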